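Swapping phenyl for bromo on a shared core

A few compounds are considered here, and "the series" means these few. Any claim that something is new, unique, unknown or untested is made for them only; others in the source may bear on it.

Compound 2 (`CCCNC(=O)[C@@H]1C[C@H]2CCC[C@@H](C1)[C@@H]2NC(=O)c1cc2sc(-c3ccccc3)nc2n1Cc1ccc(OC)cc1`) is the starting point. In an ADME assay on microsomes from liver (Homo sapiens) for metabolic stability (on this read-out higher numbers stand for a longer-lived compound and lower numbers for a shorter-lived compound), compound 2 gives 0.453 h. That lies within the scatter of compound 1 (`CCCNC(=O)[C@@H]1C[C@H]2CCC[C@@H](C1)[C@@H]2NC(=O)c1cc2scnc2n1Cc1ccc(OC)cc1`), where compound 1 gives 0.743 h and carries hydrogen in place of the phenyl. Compound 4 (`CCCNC(=O)[C@@H]1C[C@H]2CCC[C@@H](C1)[C@@H]2NC(=O)c1cc2sc(Br)nc2n1Cc1ccc(OC)cc1`) changes compound 2 at that same aromatic carbon: bromo in place of phenyl on an aromatic carbon. Among the compounds with values here, the one measured step at this carbon is a 1.6-fold lower number from compound 1 to compound 2 (0.21 log units; within the scatter), so exchanging hydrogen for phenyl there did not move the number beyond the scatter. Compound 3 (`COc1ccc(Cn2c(C(=O)N3CCC(C(=O)NC(C)C)CC3)cc3sc(Br)cc32)cc1`) also carries a bromo, but its core and side chains differ, and in this assay compound 3 gives 0.0627 h; 0.0888 h; 0.0633 h (3 entries), much smaller numbers than the other two. It is a caution for the low end rather than a measure of the swap itself. With compound 1 at 0.743 h as the guide, no step beyond the scatter is expected in this assay. The expected change is a 1.1-fold lower number from compound 2 to compound 4 (0.05 log units; within the scatter). For compound 4 the estimated half-life is 0.4 h, with an expected range from 0.13 h to 0.85 h.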

Compound 4, half-life: 0.867 h
The estimate for compound 4 lay 2.2-fold (0.34 log units) below the measured number, and the stated range ends below it.
By their numbers in this assay, from the lowest: compounds 2, 1 and 4 (each within the scatter of the next).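

At this aromatic carbon, next to the ring nitrogen and the ring sulfur, three groups can now be compared in this assay: hydrogen, phenyl and bromo. With a 1.9-fold higher number from compound 2 to compound 4 (0.28 log units; within the scatter) and a 1.2-fold higher number from compound 1 to compound 4 (0.07 log units; within the scatter) both new steps stay inside the scatter, so this read-out does not separate bromo, with its 1 heavy atom, from phenyl, with its 6, or from plain hydrogen. Nothing shown here explains why the half-life holds so steady across these groups.

As far as these compounds go, whether an amine or a carboxylic acid on this carbon would also stay within the scatter remains open. From the compounds shown here alone, all of these steps also sit on one shared core, and how bromo in place of phenyl reads on any other core is equally open.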